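Adding Trifluoromethyl to the Phenyl Ring of Compound 3

This account rests on a few compounds, and the source may have more. Where it says the series, first, only, none or still open, it means among the compounds named here.

This study measures how well a series of compounds slow the growth of breast cancer cells, using a functional assay on MCF7 cells (Homo sapiens) for inhibition, read by CCK-8 assay, with a stated time of 48 h; on this read-out higher numbers stand for weaker inhibition and lower numbers for stronger inhibition. Compound 1, with structure `COc1ccc(-c2cc3nccc(-c4cc(OC)c(OC)c(OC)c4)n3n2)cc1[N+](=O)[O-]`, gives only a limit in this assay, > 10000 nM. Compound 2, with structure `COc1cc(-c2ccnc3cc(-c4ccc(-c5cnn(C)c5)cc4)nn23)cc(OC)c1OC`, gives 274 nM. Compound 3, with structure `COc1cc(-c2ccnc3cc(-c4ccccc4)nn23)cc(OC)c1OC`, gives 254 nM, which is the lowest of the two numbers measured outright, although compound 2 sits within the scatter of it.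

Going by the values given here, the one measured step that compares directly, a 1.1-fold lower number from compound 2 to compound 3 (0.03 log units; within the scatter), replaced 1-methyl-1H-pyrazol-4-yl with hydrogen on an aromatic carbon and changed essentially nothing.

Compound 4, with structure `COc1cc(-c2ccnc3cc(-c4ccc(C(F)(F)F)cc4)nn23)cc(OC)c1OC`, is the untested compound. It differs from compound 3 by trifluoromethyl in place of hydrogen on an aromatic carbon, a small group entering where a hydrogen sat on the same aromatic carbon from which the earlier group was removed. Since swapping a sizeable group for hydrogen at that position left the number where it was, a small group entering there is expected to leave the number within the scatter as well, in either direction.

Compound 4 is therefore expected to give about 300 nM, with a likely range from 100 nM to 1000 nM. This corresponds to an expected step of a 1.2-fold higher number from compound 3 to compound 4 (0.07 log units; within the scatter).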

Compound 4, half-maximal inhibitory concentration: 2440 nM
Compound 4: the middle estimate sits 8.1-fold (0.91 log units) below what was measured; the measured number lies above the stated range.
By their numbers in this assay, from the lowest: compounds 3 and 2 (each within the scatter of the next); then compound 4. At a limit, above all of these: compound 1.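

The same place on the phenyl ring is therefore not indifferent to what sits there: in this assay trifluoromethyl brings a 9.6-fold higher number from compound 3 to compound 4 (0.98 log units; beyond the scatter), whereas the earlier pair of compound 2 and compound 3 showed no step beyond the scatter. Heavy-atom count alone does not order these results, since the larger 1-methyl-1H-pyrazol-4-yl group in compound 2 stays within the scatter of hydrogen, while the four heavy atoms of trifluoromethyl give an 8.9-fold higher number from compound 2 to compound 4 (0.95 log units; beyond the scatter), so the identity of the group counts here, not just whether the place is filled. Nothing measured here explains why this one group raises the number.

Going by these compounds alone, with only three groups compared at this place, it remains open whether the rise is peculiar to trifluoromethyl or would also appear with a single fluorine, a methyl, an amine or a carboxylic acid. On these data alone, it is also open whether trifluoromethyl would have the same effect at another carbon of the phenyl ring, or whether a different group could bring the number lower than those of compound 2 and compound 3.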